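The compounds below may be only part of what the source reports. "The series", "measured", "known", "first", "only" and "open" are said of these compounds alone.

Measured compounds:
- compound 1 `Cc1ccc(NC(=O)CN2CCN(c3nnc(Cc4ccccc4)c4ccccc34)CC2)c(C)c1`: "not active" (no number reported)
- compound 2 `O=C(CN1CCN(c2nnc(Cc3ccccc3)c3ccccc23)CC1)Nc1ccc(F)c(C(F)(F)F)c1`: 2480 nM
- compound 3 `O=C(CN1CCN(c2nnc(Cc3ccccc3)c3ccccc23)CC1)Nc1ccc(Br)cc1`: 2000 nM

In a functional assay on A549 cells (Homo sapiens) for cytotoxicity, read by MTT assay, with a stated time of 72 h (on this read-out lower numbers stand for stronger inhibition and higher numbers for weaker inhibition), compound 3 gives the lowest of the two reported numbers, yet a 1.2-fold lower number from compound 2 to compound 3 (0.09 log units; within the scatter), so compound 3 and compound 2 cannot be told apart here. Compound 1, with its dimethylphenyl on the amide-type nitrogen, gave no number.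

Compound 4 `O=C(CN1CCN(c2nnc(Cc3ccccc3)c3ccccc23)CC1)Nc1cc(C(F)(F)F)ccc1Cl` keeps the shared core and changes only the aryl on the amide-type nitrogen: 2-chloro-5-(trifluoromethyl)phenyl in place of 4-bromophenyl on an amide-type nitrogen

Among the measured compounds shown here, the one measured step bearing on this, an aryl swap at the same position, is a 1.2-fold lower number from compound 2 to compound 3 (0.09 log units; within the scatter). With a halogenated, trifluoromethyl-bearing phenyl entering again, a step of no more than the scatter is expected, direction uncertain; the estimate therefore reads a 1.3-fold higher number from compound 3 to compound 4 (0.10 log units; within the scatter). Compound 4 is estimated at 2500 nM, range 1000 nM to 7000 nM, with some chance of no number, as for compound 1.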

Compound 4, half-maximal inhibitory concentration: 89000 nM
Compound 4: the middle estimate sits 36-fold (1.55 log units) below what was measured; measured number outside the range, above it.
By their numbers in this assay, from the lowest: compounds 3 and 2 (each within the scatter of the next); then compound 4.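

In this assay the aryl on the amide-type nitrogen proves sensitive: a 45-fold higher number from compound 3 to compound 4 (1.65 log units; beyond the scatter) and a 36-fold higher number from compound 2 to compound 4 (1.55 log units; beyond the scatter) are both large, while the swap between compound 2 and compound 3 stayed within the scatter. Compound 2 also carries trifluoromethyl and a halogen, so their mere presence does not go with the high number; only the 2-chloro-5-(trifluoromethyl)phenyl pattern does. No measurement at hand accounts for this.

As far as these compounds go, whether chlorine or the trifluoromethyl placement carries the loss remains open. From the compounds shown here alone, how a pyridine ring or a carboxylic acid on this aryl would read is also open.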